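Menthyl esters: chloro to methyl on the aromatic ring

This account rests on a few compounds, and the source may have more. Where it says the series, first, only, none or still open, it means among the compounds named here.

Measured compounds in the series:
- compound 1, `CC(C)[C@@H]1CC[C@@H](C)C[C@H]1OC(=O)c1cccc(Cl)c1`: 5.34
- compound 2, `CC(C)[C@@H]1CC[C@@H](C)C[C@H]1OC(=O)CCl`: 3.5
- compound 3, `CC(C)[C@@H]1CC[C@@H](C)C[C@H]1OC(=O)c1ccccc1Cl`: 5.34

In a physicochemical assay for lipophilicity, measured as octanol-water partition (a lower number here means a more polar compound, a higher number a more lipophilic compound), compound 1 gives 5.34. Compound 1 stands level with compound 3 at the digits read; together they are the highest of the three numbers, and the gap between them lies within the scatter, so no order between them can be stated. Furthest from compound 1 stands compound 2, which gives 3.5, a gap that is beyond the scatter. Among the compounds with values here, nothing more than these two values can be said of that pair, since no step between measured compounds is available.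

Compound 4, `Cc1cccc(C(=O)O[C@@H]2C[C@H](C)CC[C@H]2C(C)C)c1`, has not yet been measured in this assay. It is derived from compound 1 by the change (methyl in place of chloro on an aromatic carbon), on an aromatic carbon of a six-membered aromatic ring of carbon only, meta to a large group. Chloro and methyl each count one heavy atom, with no donors or acceptors entering or leaving. The step from compound 1 to compound 4 is therefore expected to be small, at most a slight move downward, and likely within the scatter.

For compound 4 the expected result in this assay is 5.2, with a range of 4.9 to 5.5, which amounts to an estimated step of a number 0.14 log units lower from compound 1 to compound 4 (within the scatter).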

Compound 4, partition coefficient: 5.29
Estimate against measurement, compound 4: 0.09 log units below; measured number inside the range.
By their numbers in this assay, from the lowest: compound 2; then compounds 4, 1 and 3 (each within the scatter of the next).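

In this assay, within the data shown here, methyl in place of chloro on an aromatic carbon, meta to a large group, gives a number 0.05 log units lower from compound 1 to compound 4 (within the scatter) and is the only step between compounds that differ in one place. At this position on the shared core, the read-out does not separate chloro from methyl: one heavy atom replaces another, no hydrogen-bond donors or acceptors enter or leave, and the two compounds stand level within the scatter. No measured information is available to explain why these two groups read alike.

The series leaves open how far this position tolerates change in this read-out, since an amine, a carboxylic acid, a methoxy group or a longer chain at the same aromatic carbon could give a quite different number from the one chloro and methyl share. It also leaves open whether the same exchange of methyl for chloro would read alike on compound 3, where the chloro sits elsewhere on the ring, and so whether this result carries beyond this one place.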